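Replacing the 3-methyl-1,2-oxazol-5-yl group of compound 1

The source may hold more compounds than are shown below. What is called first, only, known or untested is meant among the compounds shown, and "the series" means these compounds.

In an ADME assay on microsomes from liver (Homo sapiens) for metabolic stability, with a stated time of 60 min, tested at 1 uM (a lower number here means that less of the compound is left, a higher number that more of the compound is left), compound 1 `COc1cc(-c2cnn3cc(OC)c(-c4cc(C)no4)nc23)ccn1` gives 31%, the lowest of the three numbers at hand. Compound 2 `COc1cc(-c2cnn3cc(OC)c(C)nc23)ccn1` gives 44%, and compound 3 `COc1cn2ncc(-c3ccnc(OC4CC4)c3)c2nc1-c1cnn(C)c1` gives 47%. Compound 4 `COc1cc(-c2cnn3cc(OC)c([C@H]4COC(C)(C)C4)nc23)ccn1` has not yet been measured. It keeps the core of compound 1 and differs in one place: a group of 7 heavy atoms (6 carbon, 1 oxygen; one five-membered non-aromatic ring with 1 hetero atom) in place of a group of 6 heavy atoms (4 carbon, 1 nitrogen, 1 oxygen; one five-membered aromatic ring with 2 hetero atoms), on an aromatic carbon. The entering group carries 1 defined stereocentre.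

For the measured compounds named here, one measured step bears on this change: a number 13 percentage points higher from compound 1 to compound 2 (beyond the scatter). There, methyl takes the place of the same 3-methyl-1,2-oxazol-5-yl group on the same aromatic carbon. This step shows that the group can leave without the number falling, but methyl is much smaller than the group entering compound 4. Going by the values given here, no measured compound carries that five-membered non-aromatic ring, so the data offer no direct guide to it. Compound 3 differs from compound 1 in more than one place and adds only a second value near the upper end of the numbers.

A small upward move is therefore expected, less than the measured step, and with wide uncertainty. The expected step in this assay is a number 7 percentage points higher from compound 1 to compound 4 (within the scatter). For compound 4 the estimated value is 38%, with an expected range from 22% to 55%.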

Compound 4, percent of the compound remaining: 21%
Compound 4: the middle estimate sits 17 percentage points above what was measured; the whole stated range lies above it.
By their numbers in this assay, from the lowest: compounds 4 and 1 (each within the scatter of the next); then compounds 2 and 3 (each within the scatter of the next).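

At this aromatic carbon in this assay, the five-membered non-aromatic ring and the 3-methyl-1,2-oxazol-5-yl group give a number 10 percentage points lower from compound 1 to compound 4 (within the scatter) and so cannot be told apart, which shows that exchanging the aromatic ring for this non-aromatic one does not bring the number up to that of compound 2. Set against methyl, the same ring gives a number 23 percentage points lower from compound 2 to compound 4 (beyond the scatter) and this step lies beyond the scatter, as does a number 13 percentage points higher from compound 1 to compound 2 (beyond the scatter) in the opposite direction. Of the three groups compared at this carbon, methyl therefore stands apart from the two five-membered rings, which cannot be separated from each other, and nothing measured here says why the numbers fall this way.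

Two rings and one methyl cannot show whether the number follows the count of heavy atoms at this carbon, or how the opposite stereoisomer of the ring would read. Also open, as far as these compounds go, is where groups of intermediate count, such as an ethyl or cyclopropyl group, or a ring carrying an amine, such as a morpholine, would stand.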